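A few compounds are considered here, and "the series" means these few. Any claim that something is new, unique, unknown or untested is made for them only; others in the source may bear on it.

Compound 1 `CCN(CC)c1cc(C)nc(N(CC)c2ccc(C(C)=O)cc2Br)n1` gives 5 nM in an assay on isolated protein for binding affinity to corticotropin-releasing factor receptor 1 (Homo sapiens) (a lower number here means a stronger inhibitor, a higher number a weaker inhibitor), the lowest of the two numbers in this set. Compound 2 `CCN(c1nc(C)cc(C)n1)c1c(Br)cc(C(C)C)cc1SC` gives 51 nM in this assay, a gap from compound 1 that lies beyond the scatter. Compound 3 `CCCCN(Cc1nn[nH]n1)c1cc(C)nc(N(CC)c2ccc(C(C)C)cc2Br)n1` returns only a limit in this assay, > 1000 nM, which is the limit of > 1000 nM in this assay, at which 1 of the 3 values shown sits. Compound 4 `CCN(CC)c1cc(C)nc(N(CC)c2c(Br)cc(C(C)=O)cc2OC)n1` has not yet been measured; it differs from compound 1 by methoxy in place of hydrogen on an aromatic carbon. For the measured compounds named here, with no measured pair carrying this change, the step is expected to be small, in either direction or none beyond the scatter. Compound 4 is therefore estimated to give 8 nM in this assay, within 2 nM to 30 nM, a step of a 1.6-fold higher number from compound 1 to compound 4 (0.20 log units; within the scatter).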

Compound 4, inhibition constant: 28 nM
For compound 4 the middle estimate is 3.5-fold (0.54 log units) below the measured one; the range from low to high includes it.
By their numbers in this assay, from the lowest: compound 1; then compounds 4 and 2 (each within the scatter of the next). At a limit, above all of these: compound 3.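

Methoxy in place of hydrogen on this aromatic carbon brings a 5.6-fold higher number from compound 1 to compound 4 (0.75 log units; beyond the scatter) in this assay, which shows that this position of the core of compound 1 does not accept the change without cost. For the compounds shown here, the earlier compounds offered no pair that differed at this place, so this is the only direct reading of it. Nothing measured here bears on the cause of this step. The compounds shown leave open how fluoro, a hydroxyl or a longer ether such as ethoxy would fare on this carbon. They also leave open whether the step would hold with different groups elsewhere on the core.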